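Cytotoxicity of Three Halogenated Analogues and a Fourth to Come

This account rests on a few compounds, and the source may have more. Where it says the series, first, only, none or still open, it means among the compounds named here.

Compound 1 `O=[N+]([O-])c1cc(CSc2nnc(-c3ccc(Cl)cc3)n2Cc2ccccc2)cc([N+](=O)[O-])c1` in an ADME assay on A-431 cells (Homo sapiens) for cytotoxicity, with a stated time of 48 h (a higher number here means a weaker inhibitor, a lower number a stronger inhibitor), gives only a limit, > 30000 nM.
Compound 2 `O=[N+]([O-])c1cc(CSc2nnc(-c3ccc(Br)cc3)n2Cc2ccccc2)cc([N+](=O)[O-])c1` in this assay gives only a limit, > 30000 nM.
Compound 3 `Cn1c(SCc2ccc(Br)cc2)nnc1-c1cc([N+](=O)[O-])cc([N+](=O)[O-])c1` in this assay gives only a limit, > 30000 nM.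

Compound 1 and compound 2 share one core and differ in a single place, (chloro in place of bromo on an aromatic carbon). Because all three values sit at the same limit, (the limit of > 30000 nM in this assay, at which 3 of the 3 values shown sit), the step that the two limits leave unreadable from compound 2 to compound 1 cannot be read as a number. Compound 3 carries a different core; the difference between the two cores is not broken down here.

Compound 4 `Cn1c(SCc2ccc(Cl)cc2)nnc1-c1cc([N+](=O)[O-])cc([N+](=O)[O-])c1` stands to compound 3 exactly as compound 1 stands to compound 2, (chloro in place of bromo on an aromatic carbon), the same change made at the same kind of place. From compound 3 to compound 4 the step in this assay is expected to be small, a step that the limit leaves unreadable from compound 3 to compound 4, because compound 3 already sits at the limit > 30000 nM and the matching change left compound 1 and compound 2 both at that limit. Compound 4 is therefore estimated to fall at or beyond the limit as well, around 50000 nM, plausibly between 20000 nM and 200000 nM.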

Compound 4, half-maximal inhibitory concentration: > 30000 nM
Compound 4 ended at the assay's limit; the forecaster's own chance of this, stated with the estimate: 85%; the middle value does not contradict the limit.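

Compound 3 and compound 4 each give a limit rather than a number, so no size can be read for the change from bromo to chloro between them: the limit of > 30000 nM in this assay, at which 4 of the 4 values shown sit.

The compounds shown leave open whether chloro and bromo differ at all in this assay, and what change, if any, would bring a value within the measurable range.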